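This account rests on a few compounds, and the source may have more. Where it says the series, first, only, none or still open, it means among the compounds named here.

Compound 1 `Cc1n[nH]c(-c2ccccc2NCC2=NCCN2)n1` gives 87% in a functional assay with Alpha-1A adrenergic receptor (Homo sapiens) as the target, read by calcium flux; on this read-out higher numbers stand for larger maximal responses and lower numbers for smaller maximal responses.
Compound 2 `Cn1ncnc1-c1ccccc1NCC1=NCCN1` gives 91% in this assay.

Of the two numbers shown, compound 2 and compound 1 sit within the scatter of each other, so neither can be set above the other; the one measured step, a number 4 percentage points higher from compound 1 to compound 2 (within the scatter), says the same. Compound 3 `c1ccc(-c2nc[nH]n2)c(NCC2=NCCN2)c1` is not yet measured. It differs from compound 2 in one place: 1H-1,2,4-triazol-3-yl in place of 1-methyl-1H-1,2,4-triazol-5-yl on an aromatic carbon. Among the measured compounds shown here, the only step so far, a number 4 percentage points higher from compound 1 to compound 2 (within the scatter), concerns the same ring and left this assay essentially unchanged. That step does not test taking the methyl away or joining the ring through a different atom, so it bears on the new change only loosely. With nothing pointing in either direction, the step expected is a number 5 percentage points lower from compound 2 to compound 3 (within the scatter), no change beyond the scatter, with a wider uncertainty than usual. Compound 3 is therefore estimated at 86% in this assay, within a range from 68% to 102%.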

Compound 3, largest response reached (reported as maximal response), in percent of the reference or control that the assay uses: 135%
Beside the measured number, compound 3's estimate is 49 percentage points below it; measured number above the stated range.
By their numbers in this assay, from the lowest: compounds 1 and 2 (each within the scatter of the next); then compound 3.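

In this assay the triazole on this aromatic carbon proves to matter a great deal: putting 1H-1,2,4-triazol-3-yl in place of 1-methyl-1H-1,2,4-triazol-5-yl gives a number 44 percentage points higher from compound 2 to compound 3 (beyond the scatter) and putting it in place of 3-methyl-1H-1,2,4-triazol-5-yl gives a number 48 percentage points higher from compound 1 to compound 3 (beyond the scatter) in the same read-out. Among these three compounds, the two triazoles that carry a methyl group sit close together, while the one without a methyl group stands clearly higher. No measurement shown here explains this rise in maximal response.

Going by these compounds, compound 2 and compound 3 differ both in the methyl group and in the ring atom that joins the triazole to the core, so the effect of each alone stays open. Also open, on these data alone, is how this read-out would respond to an ethyl group on the triazole, or to an amine or a carboxylic acid in its place.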